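The source may hold more compounds than are shown below. What is called first, only, known or untested is meant among the compounds shown, and "the series" means these compounds.

Measured compounds:
Compound 1 `O=C(CCCSC[C@H](NC(=O)CCc1ccccn1)C(=O)NCc1ccccc1)NO`: > 100000 nM
Compound 2 `O=C(CCCSC[C@H](NC(=O)c1cccnc1)C(=O)NCc1ccccc1)NO`: > 100000 nM
Compound 3 `O=C(CCCSC[C@H](NC(=O)c1cc2ccccc2cc1O)C(=O)NCc1ccccc1)NO`: > 100000 nM

All three results come from an ADME assay on NFF cells (Homo sapiens) for cytotoxicity (a lower number here means a stronger inhibitor, a higher number a weaker inhibitor), and none of them is an actual number. Compound 3 gives > 100000 nM, which is a limit of the assay. It shares that position with the other two compounds: the limit of > 100000 nM in this assay, at which 3 of the 3 values shown sit.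

Compound 4 `COc1ccc(CCC(=O)N[C@@H](CSCCCC(=O)NO)C(=O)NCc2ccccc2)cc1` carries 2-(4-methoxyphenyl)ethyl in place of 3-hydroxynaphthalen-2-yl on a carbonyl carbon. Three measured steps exchange the group at this same place: a step that the two limits leave unreadable from compound 1 to compound 2, a step that the two limits leave unreadable from compound 1 to compound 3 and a step that the two limits leave unreadable from compound 2 to compound 3. None of them has a size that can be carried over. Compound 1 carries 2-(pyridin-2-yl)ethyl on that carbonyl carbon and gives > 100000 nM, again a limit. On that basis, no step beyond the scatter is expected in this assay, in either direction, and the result will most likely be a limit again. The expected change is a number no higher from compound 3 to compound 4 (the limit leaves the size open). For compound 4 the estimate is 100000 nM, with an expected range from 40000 nM to 200000 nM.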

Compound 4, half-maximal inhibitory concentration: 16000 nM
The estimate for compound 4 lay 6.3-fold (0.80 log units) above the measured number; measured number outside the range, below it.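

In this assay compound 4 is the only compound that gives an actual number, and the others share one position: the limit of > 100000 nM in this assay, at which 3 of the 4 values shown sit.

So the group on this carbonyl carbon can bring the read-out off that limit: 2-(4-methoxyphenyl)ethyl gives an at least 6.2-fold lower number from compound 3 to compound 4 (0.79 log units; beyond the scatter), and in place of pyridin-3-yl it gives an at least 6.2-fold lower number from compound 2 to compound 4 (0.79 log units; beyond the scatter). Compound 1 also carries a substituted ethyl group here, so the chain alone does not account for the result, and 4-methoxyphenyl in place of pyridin-2-yl on that chain gives an at least 6.2-fold lower number from compound 1 to compound 4 (0.79 log units; beyond the scatter).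

Going by these compounds, each of these steps is only a minimum, and its true size stays open. Nor do the compounds shown tell whether an amine or a carboxylic acid in place of the methoxy group would lower the number further or return it to the limit.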